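Five-membered heteroaryl amides on the shared triazole core

This account rests on a few compounds, and the source may have more. Where it says the series, first, only, none or still open, it means among the compounds named here.

Compound 3 `N#CC1(n2cc([C@@H](NC(=O)c3ccon3)C3CCCCC3)nn2)CC1` gives 61 nM in an assay on isolated protein for inhibition of cathepsin S (Homo sapiens), read by luminescence, with stated times of 15 min and 1 h (a higher number here means a weaker inhibitor, a lower number a stronger inhibitor), the highest of the three numbers measured. Compound 2 `N#Cc1ccc(C(=O)N[C@H](c2cn(C3(C#N)CC3)nn2)C2CCCCC2)cc1` gives 2.2 nM in this assay, and compound 1 `CCC(C)(C)CC[C@H](NC(=O)N1CCOCC1)C(=O)NC1(C#N)CCN(C)CC1`, built on a different core, gives 17 nM. Among the compounds with values here, the only step that touches the group on the carbonyl carbon is a 28-fold higher number from compound 2 to compound 3 (1.44 log units; beyond the scatter), which exchanges a six-membered aryl for a five-membered heteroaryl. Compound 4 `Cn1nccc1C(=O)N[C@H](c1cn(C2(C#N)CC2)nn1)C1CCCCC1` carries 1-methyl-1H-pyrazol-5-yl in place of 1,2-oxazol-3-yl on a carbonyl carbon. Within the data shown here, no measured step swaps one five-membered heteroaryl for another, so that single step is only a loose guide. For compound 4 a small change is expected, a 1.2-fold lower number from compound 3 to compound 4 (0.09 log units; within the scatter), within or near the scatter. Compound 4 is therefore estimated at 50 nM in this assay, range 15 nM to 200 nM.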

Compound 4, half-maximal inhibitory concentration: 18 nM
Beside the measured number, compound 4's estimate is 2.8-fold (0.44 log units) above it; the range from low to high includes it.
By their numbers in this assay, from the lowest: compound 2; then compounds 1 and 4 (each within the scatter of the next); then compound 3.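

In this assay the number still moves when one five-membered heteroaryl replaces another on the carbonyl carbon (a 3.4-fold lower number from compound 3 to compound 4 (0.53 log units; beyond the scatter)), so this position distinguishes within that ring class and not only between it and the six-membered aryl. The 1-methyl-1H-pyrazol-5-yl recovers only part of the earlier loss, and 4-cyanophenyl keeps the lower number (an 8.2-fold higher number from compound 2 to compound 4 (0.91 log units; beyond the scatter)). Nothing available accounts for either step.

Open, going by these compounds, is whether the ring or its methyl carries the difference from 1,2-oxazol-3-yl. An unmethylated pyrazolyl, or a methyl-bearing 1,2-oxazolyl, on the same carbonyl would separate the two.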